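Removal of one methoxy on the aryl ring of a quinazoline-piperazine series

A few compounds are considered here, and "the series" means these few. Any claim that something is new, unique, unknown or untested is made for them only; others in the source may bear on it.

Measured so far:
compound 1 `COc1ccc(-c2nc(N3CCNCC3)nc3ccccc23)c(OC)c1` — in a functional assay on KB cells (Homo sapiens) for antiproliferative activity, read by MTT assay (on this read-out higher numbers stand for weaker inhibition and lower numbers for stronger inhibition), compound 1 gives 50 ug/mL
compound 2 `COc1cc(OC)c(-c2nc(N3CCN(C)CC3)nc3ccccc23)c(OC)c1` — in this assay compound 2 gives 50 ug/mL

Compound 2 stands level with compound 1 at the digits reported; the two values lie within the scatter of each other, so the numbers show no difference between them. Compound 3 `COc1ccc(-c2nc(N3CCN(C)CC3)nc3ccccc23)c(OC)c1` has not yet been measured in this assay. It differs from compound 2 in one place: hydrogen in place of methoxy on an aromatic carbon. For the measured compounds named here, nothing measured bears directly on this change; the only comparison available, compound 1 against compound 2, shows two compounds of different methoxy count and different piperazine substitution sitting at the same reading. On that basis no step beyond the scatter is expected, and the step of no change at the digits printed from compound 2 to compound 3 (within the scatter) is estimated to be flat. Compound 3 is expected to give about 50 ug/mL, with a range from 25 ug/mL to 100 ug/mL.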

Compound 3, half-maximal inhibitory concentration: 50 ug/mL
Compound 3: the middle estimate sits on the measured number at the digits printed; the range from low to high includes it.
By their numbers in this assay, from the lowest: compounds 1, 2 and 3 (each within the scatter of the next).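

In this assay, for the compounds shown here, hydrogen in place of methoxy on an aromatic carbon, ortho to a large group, gives no change at the digits printed from compound 2 to compound 3 (within the scatter), the first comparison at this position that differs in one place only. Methyl in place of hydrogen on an amine nitrogen in a ring gives no change at the digits printed from compound 1 to compound 3 (within the scatter), a single-change reading that compound 1 and compound 2, which differ in two places, could not supply. Nothing at hand offers an explanation for either flat step.

On these data alone, whether another group on this aromatic carbon, such as an amine or a carboxylic acid, would move the reading stays open. Also open, as far as these compounds go, is whether a longer chain, such as propyl, on the ring nitrogen would shift the value in this assay, since these compounds all read alike.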